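Swapping a Catechol Amine for a Benzyl Amide

The compounds below may be only part of what the source reports. "The series", "measured", "known", "first", "only" and "open" are said of these compounds alone.

This study follows a family of compounds built on a shared core, tested in a functional assay on BMMC cells (Mus musculus, strain C57BL/6) for inhibition, with stated times of 5 days and 48 h; on this read-out lower numbers stand for stronger inhibition and higher numbers for weaker inhibition. Two of them have been measured. Compound 1, with the structure `C=C1CC[C@@H]2[C@](C)(CO)[C@H](O)CC[C@@]2(C)[C@@H]1C/C=C(/C(=O)O)[C@H](O)CO`, gives in this assay only a limit of the assay, > 30000 nM, and no number. Within the data shown here, compound 2, with the structure `C=C1CC[C@@H]2[C@](C)(CNCc3ccc(O)c(O)c3)[C@H](O)CC[C@@]2(C)[C@@H]1/C=C/C1=CCOC1=O`, is the only compound of the two that gives a number at all: in this assay compound 2 gives 9440 nM. Among the measured compounds shown here, since the one other result is a limit, no step between measured compounds can be stated, and compound 2 simply stands as the single compound with a measured figure.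

The next compound, compound 3, has the structure `C=C1CC[C@H]2[C@@](C)(CC[C@@H](O)[C@@]2(C)C(=O)NCc2ccccc2)[C@@H]1/C=C/C1=CCOC1=O`. It differs from compound 2 in one place: a group of 10 heavy atoms (8 carbon, 1 nitrogen, 1 oxygen; one six-membered aromatic ring of carbon only) in place of a group of 11 heavy atoms (8 carbon, 1 nitrogen, 2 oxygen; one six-membered aromatic ring of carbon only), on a saturated ring carbon. For the measured compounds named here, with no measured step to lean on, the expectation for this change is cautious: a step from compound 2 to compound 3 of about a 1.6-fold higher number from compound 2 to compound 3 (0.20 log units; within the scatter) toward weaker inhibition is expected, though it may well stay within the scatter. Compound 3 is therefore expected to give about 15000 nM in this assay, within a range from 4000 nM to 40000 nM.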

Compound 3, half-maximal inhibitory concentration: 19400 nM
For compound 3 the middle estimate is 1.3-fold (0.11 log units) below the measured one; measured number inside the range.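

Among these compounds, this is the first measured step on the shared core: in this assay, benzylcarbamoyl in place of the catechol amine group on the saturated ring carbon gives a 2.1-fold higher number from compound 2 to compound 3 (0.31 log units; beyond the scatter), a modest change just beyond the usual scatter. The position therefore accepts a group with fewer hydrogen-bond donors and acceptors, at a modest cost, and the result is still a measured number. That number cannot be taken for granted on this read-out, as compound 1 gives only a limit of the assay and no number: the limit of > 30000 nM in this assay, at which 1 of the 3 values shown sits.

The step changes two things at once, the amine link becoming an amide and the two hydroxy groups leaving the aromatic ring, and the compounds shown do not tell these two changes apart. Still open, from the compounds shown here alone, is how a plain benzyl amine, a catechol amide or a carboxylic acid on a longer chain would behave at this position.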